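A few compounds are considered here, and "the series" means these few. Any claim that something is new, unique, unknown or untested is made for them only; others in the source may bear on it.

Measured so far:
compound 1 `CN(C)CCNc1nc(-c2ccc(NC(=O)Nc3ccccc3F)cc2)nc2ccsc12` — 530 nM
compound 2 `CN(C)CCNc1nc(-c2ccc(NC(=O)Nc3ccc(Cl)cc3)cc2)nc2ccsc12` — 250 nM
compound 3 `CCN(CC)CCCNc1nc(-c2ccc(NC(=O)Nc3ccccc3)cc2)nc2c(Cl)c(Cl)sc12` — 1640 nM

In a functional assay on MKN-45 cells (Homo sapiens) for cytotoxicity, read by MTT assay, with a stated time of 72 h (a lower number here means a stronger inhibitor, a higher number a weaker inhibitor), compound 3 gives the highest number of the three, and so is the weakest inhibitor here; both compound 1 and compound 2 sit at lower numbers. Compound 4 `CCN(CC)CCCNc1nc(-c2ccc(NC(=O)Nc3ccc(C)cc3)cc2)nc2c(Cl)c(Cl)sc12` differs from compound 3 by methyl in place of hydrogen on an aromatic carbon, on the phenyl that hangs from the urea nitrogen at the far end of the molecule. For the measured compounds named here, only one measured step bears on this position: a 2.1-fold lower number from compound 1 to compound 2 (0.33 log units; beyond the scatter), which swapped one halogen-bearing phenyl for another and moved the number by a modest amount. Going by the values given here, it is not the same change, and no measured pair tests a plain methyl added to an otherwise unsubstituted phenyl. Among the compounds with values here, since the one related step was small, compound 4 is expected to land close to compound 3, with at most a modest shift in either direction and a slight lean toward a lower number. The estimate for compound 4 in this assay is 1100 nM, with a range of 400 nM to 3000 nM, meaning an expected step of a 1.5-fold lower number from compound 3 to compound 4 (0.17 log units; within the scatter).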

Compound 4, half-maximal inhibitory concentration: 3320 nM
Compound 4: the middle estimate sits 3.0-fold (0.48 log units) below what was measured; the whole stated range lies below it.
By their numbers in this assay, from the lowest: compound 2; then compound 1; then compound 3; then compound 4.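

In this assay, adding one methyl to the far phenyl, para to a large group, gives a 2.0-fold higher number from compound 3 to compound 4 (0.31 log units; beyond the scatter) and so makes for a weaker inhibitor by a modest but real amount. For the compounds shown here, this is the only measured step that starts from a plain phenyl, and its direction is opposite to that of the halogen swap on the other core, which gave a 2.1-fold lower number from compound 1 to compound 2 (0.33 log units; beyond the scatter) in the same assay. Nothing measured here explains the rise in the number.

Still open, going by these compounds, is whether a methoxy group or a chlorine at this same place would also raise the number, or whether the effect is specific to methyl. On these data alone, it is equally open whether the same methyl would act in the same way on the core and dimethylaminoethyl chain of compound 1.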